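The compounds below may be only part of what the source reports. "The series", "measured", "known", "first", "only" and "open" are said of these compounds alone.

In a functional assay on A549 cells (Homo sapiens) for antiproliferative activity, with a stated time of 5 days (a higher number here means a weaker inhibitor, a lower number a stronger inhibitor), compound 1 `COc1ccc(-n2nc(-c3ccc4ccccc4c3)nc2N2C(=O)COC23C=CC(=O)C=C3)cc1` gives 260 nM. Compound 3 `O=C1C=CC2(C=C1)OCC(=O)N2c1nc(-c2ccc3c(c2)OCCO3)nn1-c1ccccc1` gives 170 nM, and these two values lie within the usual scatter of each other. Compound 2 `COc1ccc(-n2nc(-c3ccc4ccccc4c3)nc2N2C(=O)C(C)OC23C=CC(=O)C=C3)cc1` gives 860 nM, the highest number of the three. Among the measured compounds shown here, the only measured single change, methyl in place of hydrogen on a saturated ring carbon, is a 3.3-fold higher number from compound 1 to compound 2 (0.52 log units; beyond the scatter).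

Compound 4 `O=C1C=CC2(C=C1)OCC(=O)N2c1nc(-c2ccc3ccccc3c2)nn1-c1ccc(C(F)(F)F)cc1` keeps the core of compound 1 but alters another part of the molecule, with trifluoromethyl in place of methoxy on an aromatic carbon. That measured methyl step lies elsewhere, so it says nothing direct about this swap and gives no direction for it. For the measured compounds named here, it shows only that one small change can move the number modestly. With no measured evidence for a shift either way, the expected result is a 1.2-fold higher number from compound 1 to compound 4 (0.06 log units; within the scatter), which means no clear change beyond the scatter. For compound 4 the estimated value is 300 nM, with an expected range of 100 nM to 900 nM.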

Compound 4, half-maximal inhibitory concentration: 460 nM
The estimate for compound 4 lay 1.5-fold (0.19 log units) below the measured number; low and high end bracket the measured number.
By their numbers in this assay, from the lowest: compounds 3, 1, 4 and 2 (each within the scatter of the next, the first and the last beyond it).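

Placing trifluoromethyl where compound 1 carries methoxy, on the aromatic carbon para to a large group, gives a 1.8-fold higher number from compound 1 to compound 4 (0.25 log units; within the scatter) in this assay. Among the compounds shown here, the earlier compounds showed only a change on a saturated ring carbon, so this is the first measured reading at this aromatic position. Here, 4-methoxyphenyl and 4-(trifluoromethyl)phenyl cannot be told apart, and no measurement is available to explain the result.

This is a single pair on one core, so it sets no trend for the position, and it does not show how far the position's tolerance extends. As far as these compounds go, how an amine, a carboxylic acid or a longer chain such as butoxy would behave at this place remains open.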